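A few compounds are considered here, and "the series" means these few. Any claim that something is new, unique, unknown or untested is made for them only; others in the source may bear on it.

Compound 1, `CC(C)OCCCNC(=O)c1csc(Nc2ccc(Cl)c(Cl)c2)n1`, was measured.
Compound 2, `Cc1cc(Nc2nc(C(=O)NCCCOC(C)C)cs2)ccc1Cl`, was measured.

In an ADME assay on MDCK cells (Canis lupus familiaris) for cytotoxicity, with a stated time of 48 h (a lower number here means that less compound is tolerated, a higher number that more compound is tolerated), compound 1 gives 100000 nM. For compound 2 the result is only a limit of the assay, > 100000 nM. The step of a number no lower from compound 1 to compound 2 (the limit leaves the size open) therefore has no readable size, because the reading rests on (the limit of > 100000 nM in this assay, at which 1 of the 2 values shown sits). Compound 2 thus stands at the limit of this assay rather than at a number. Compound 3, `Cc1cc(Nc2nc(C(=O)NCCCOC(C)C)cs2)cc(C)c1Cl`, has not yet been measured in this assay. It differs from compound 2 by methyl in place of hydrogen on an aromatic carbon. For the measured compounds named here, of the measured steps, only the one from compound 1 to compound 2 bears on this change, and it sets no size, leaving the expected step open beyond showing no loss of tolerance. Compound 3 is therefore expected to stay close to the limit, with an estimated step of a number no higher from compound 2 to compound 3 (the limit leaves the size open) not beyond the scatter. The estimate for compound 3 in this assay is 100000 nM, in a range from 50000 nM to 100000 nM.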

Compound 3, half-maximal cytotoxic concentration: > 100000 nM
Compound 3: only a limit was reported; the forecaster's own chance of this, stated with the estimate: 70%; the middle value lies on the limit itself.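

In this assay compound 3 gives > 100000 nM, which is a limit and not a number. No step can be read between compound 2 and compound 3, because both results rest on a limit: the limit of > 100000 nM in this assay, at which 2 of the 3 values shown sit. The compounds shown leave open whether methyl in place of hydrogen changes how much compound is tolerated.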